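A few compounds are considered here, and "the series" means these few. Any claim that something is new, unique, unknown or untested is made for them only; others in the source may bear on it.

Compound 1, `COc1c(/C=C2/C(=O)Nc3ccc(Cl)cc32)c2ccccc2n1-c1ccccc1`, gives 2340 nM in a functional assay on cells (Leukemia cell, Homo sapiens) for cytotoxicity, with a stated time of 48 h; a lower number here means a stronger inhibitor of growth, a higher number a weaker inhibitor of growth.
Compound 2, `COc1cc2c(cc1C)NC(=O)/C2=C/c1c(Cl)n(Cc2cc(OC)c(OC)c(OC)c2)c2cc(C)c(OC)cc12`, gives 3240 nM in this assay.
Compound 3, `O=C1/C(=C/c2c(Cl)[nH]c3ccccc23)c2ccccc2N1Cc1ccccc1`, gives 2950 nM in this assay.

The three numbers sit close together, and every gap between them lies within the usual scatter of repeated measurements, so none of the three can be called the stronger or weaker inhibitor of growth on this evidence. Compound 2 therefore stands level with compound 1 and compound 3 in this assay.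

Compound 4, `COc1ccc2c(c1)/C(=C\c1c(Cl)n(Cc3cc(OC)c(OC)c(OC)c3)c3cc(C)c(OC)cc13)C(=O)N2`, has not yet been measured. It differs from compound 2 in a single place: hydrogen in place of methyl on an aromatic carbon. The change is small in size and sits on the aromatic ring of the shared core. Within the data shown here, no measured pair shows the effect of this change, so the expectation rests on the closeness of the three known numbers. Compound 4 is expected to stay within the scatter of compound 2, a step of a 1.1-fold higher number from compound 2 to compound 4 (0.03 log units; within the scatter). The estimate for compound 4 in this assay is 3500 nM, with a range from 1500 nM to 8000 nM.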

Compound 4, concentration for 50% growth inhibition: 6170 nM
For compound 4 the middle estimate is 1.8-fold (0.25 log units) below the measured one; the measured number falls inside the stated range.
By their numbers in this assay, from the lowest: compounds 1, 3, 2 and 4 (each within the scatter of the next, the first and the last beyond it).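

In this assay, among these compounds, putting hydrogen in place of methyl on this aromatic carbon, ortho to a methoxy group, gives the first step that can be read between two compounds differing in one place: a 1.9-fold higher number from compound 2 to compound 4 (0.28 log units; within the scatter). The two compounds therefore stand level, so this pair gives no sign that the methyl group at this position matters for growth inhibition in these leukemia cells. Nothing measured here bears on why the methyl group can be exchanged for hydrogen with so little visible effect.

Going by these compounds, this single pair covers only methyl and hydrogen, so it remains open whether an amine, a carboxylic acid or a longer chain on the same aromatic carbon would also stand level. On these data alone, it also remains open whether the same exchange would stand level on a shared core carrying different groups elsewhere.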